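Exchanging the aryl group on a shared quinoline-type scaffold

The source may report more compounds than this note shows. Statements on the series, on what has been measured and on what is new or still open speak of the compounds shown alone.

The three measured compounds share a common core and differ in the group attached to it and in the side chain. Compound 1 `COc1ccc(Oc2ccc3c(NCCCNCc4cc(F)ccc4OC)ccnc3c2)cc1` and compound 2 `COc1cccc(CNCCCNc2ccnc3cc(Oc4ccc(Cl)cc4)ccc23)c1O` both carry an aryl ether on the core, and in a physicochemical assay for solubility, with a stated time of 18 h, at pH 7.4 (on this read-out lower numbers stand for lower solubility and higher numbers for higher solubility), compound 1 gives 14500 nM while compound 2 gives 14500 nM, two values that lie within the scatter of each other. Compound 3 `Fc1ccc(-c2ccc3c(NCCCNCc4ccco4)ccnc3c2)cc1` carries a directly attached aryl ring and a furan-containing side chain; in this assay compound 3 gives 32000 nM, the highest of the three numbers, and its distance to each of the other two is beyond the scatter.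

Compound 4 `COc1ccc(Oc2ccc3c(NCCCNCc4ccco4)ccnc3c2)cc1` has not yet been measured. It keeps the side chain of compound 3 and differs only at the aromatic carbon of the core: 4-methoxyphenoxy in place of 4-fluorophenyl on an aromatic carbon

Within the data shown here, no step between two measured compounds isolates this exchange, so the expectation rests on compound 1, which carries the same 4-methoxyphenoxy group and gives 14500 nM. A modest decrease in solubility from compound 3 is therefore expected, of the order shown by a 1.6-fold lower number from compound 3 to compound 4 (0.20 log units; within the scatter). Compound 4 is estimated at 20000 nM, with a likely range from 8000 nM to 50000 nM.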

Compound 4, solubility: 14500 nM
Beside the measured number, compound 4's estimate is 1.4-fold (0.14 log units) above it; measured number inside the range.
By their numbers in this assay, from the lowest: compounds 1, 2 and 4 (each within the scatter of the next); then compound 3.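

In this assay, among these compounds, the exchange of 4-fluorophenyl for 4-methoxyphenoxy on this aromatic carbon, with the furan-containing side chain held constant, gives a 2.2-fold lower number from compound 3 to compound 4 (0.34 log units; beyond the scatter) and so provides the first reading of this position alone, where the earlier compounds differed in both the group on the core and the side chain. The second exchange, furan-2-yl in place of 5-fluoro-2-methoxyphenyl on a saturated chain carbon bound to an amine nitrogen, gives no change at the digits printed from compound 1 to compound 4 (within the scatter) and shows that, with 4-methoxyphenoxy on the core, this read-out does not separate these two side-chain ends. Nothing measured here explains why the first exchange moves the number while the second does not.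

The compounds shown leave open whether the step comes from the ether oxygen or from the swap of fluorine for methoxy, a question that 4-methoxyphenyl or 4-fluorophenoxy at this aromatic carbon would address. They also leave open how an amine or a carboxylic acid at the same carbon would read, and whether the step at this position would hold with the 5-fluoro-2-methoxyphenyl side chain.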